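Working notes: methoxy to carbamoyl on the compound 3 scaffold

A few compounds are considered here, and "the series" means these few. Any claim that something is new, unique, unknown or untested is made for them only; others in the source may bear on it.

Compound 1, `Clc1ccc(N2CC[C@H]3CN[C@H]3C2)cn1`, in a functional assay on HEK293 cells for agonist activity at Neuronal acetylcholine receptor; alpha4/beta2 (Homo sapiens), read by FLIPR; on this read-out higher numbers stand for an effect only at larger amounts of compound and lower numbers for an effect already at smaller amounts: 13 nM
Compound 2, `COc1cc(N2C[C@@H]3CCNC[C@@H]32)cnc1Br`, in this assay: 1690 nM
Compound 3, `COc1cc(N2C[C@H]3CCNC[C@H]32)cnc1Br`, in this assay: 200 nM

Within the data shown here, compound 3 gives the second highest of the three numbers so far in this assay. Compound 1 sits well below it, and compound 2 well above it. Among the measured compounds shown here, the only step measured within the set is an 8.5-fold lower number from compound 2 to compound 3 (0.93 log units; beyond the scatter), and since the two compounds are mirror images this step is governed by the fact that compounds 2 and 3 differ only in the configuration as drawn; it concerns configuration alone and says nothing about exchanging a substituent.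

The next compound, compound 4, `NC(=O)c1cc(N2C[C@H]3CCNC[C@H]32)cnc1Br`, keeps the ring skeleton and configuration of compound 3 and changes one group: carbamoyl in place of methoxy on an aromatic carbon.

For the measured compounds named here, no measured step in the set touches this position or either of these groups, so there is nothing here to set a direction for the change; only the value of compound 3 in this assay serves as anchor. The expectation is therefore centred on that anchor, with a wide range in both directions. Compound 4 is estimated at 300 nM, between 60 nM and 1500 nM, in this assay. This estimate means a step of a 1.5-fold higher number from compound 3 to compound 4 (0.18 log units; within the scatter) is expected, which is not a step of confident size.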

Compound 4, half-maximal effective concentration: 340 nM
Beside the measured number, compound 4's estimate is 1.1-fold (0.05 log units) below it; the range from low to high includes it.
By their numbers in this assay, from the lowest: compound 1; then compounds 3 and 4 (each within the scatter of the next); then compound 2.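

In this assay, among these compounds, carbamoyl in place of methoxy on this aromatic carbon, ortho to a bromo group, gives a 1.7-fold higher number from compound 3 to compound 4 (0.23 log units; within the scatter) and is the first measured step at this position, since the only earlier step concerned configuration alone. The position therefore accepts carbamoyl, with its hydrogen-bond donor, and the read-out cannot be told apart from that of compound 3, at least for this pair in the configuration of compound 3. Among the compounds shown here, nothing available bears on why these two groups read alike, and the single pair sets no pattern for the position.

Open, going by these compounds, is whether other groups on this aromatic carbon, such as an amine, a carboxylic acid or a longer chain, would keep the number within the scatter of compound 3 or move it beyond the scatter in this assay. Also open, on these data alone, is whether the same exchange of methoxy for carbamoyl would read alike in the mirror-image configuration of compound 2.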